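A few compounds are considered here, and "the series" means these few. Any claim that something is new, unique, unknown or untested is made for them only; others in the source may bear on it.

Compound 1 `Cc1cn([C@H]2C[C@H](N=[N+]=[N-])[C@@H](COC(=O)CCCC(=O)OCSc3ccccc3CNCCC(N)=O)O2)c(=O)[nH]c1=O`: > 1610 nM
Compound 2 `Cc1cn([C@H]2C[C@H](N=[N+]=[N-])[C@@H](COC(=O)CCCCC(=O)OCSc3ccccc3CNCCC(N)=O)O2)c(=O)[nH]c1=O`: > 1580 nM

In an ADME assay on TZM cells (Homo sapiens) for cytotoxicity, read by MTT assay, with a stated time of 5 days (a lower number here means that less compound is tolerated, a higher number that more compound is tolerated), compound 1 stands at > 1610 nM, which is a limit and not a number. Compound 2 likewise gives only a limit, > 1580 nM. Compound 3 `Cc1cn([C@H]2C[C@H](N=[N+]=[N-])[C@@H](COC(=O)CC(C)CC(=O)OCSc3ccccc3CNCCC(N)=O)O2)c(=O)[nH]c1=O` has methyl in place of hydrogen on a saturated chain carbon bound to two saturated chain carbons. For the measured compounds named here, with no measured step to draw on, the expectation in this assay is for no change beyond the scatter. The expected step is an at least 1.0-fold lower number from compound 1 to compound 3 (0.00 log units; that floor lies within the scatter). Compound 3 is estimated at 1580 nM, with an expected range of 1000 nM to 3000 nM.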

Compound 3, half-maximal cytotoxic concentration: > 1580 nM
Compound 3: a limit, no number (the forecaster's own chance of this, stated with the estimate: 90%); the middle value lies on the limit itself.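

In this assay compound 1 and compound 3 both give only limits, and the step between them cannot be read. The compounds shown leave open what concentration is actually tolerated and whether the methyl changes it.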